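The source may report more compounds than this note shows. Statements on the series, on what has been measured and on what is new or still open speak of the compounds shown alone.

Going by the values given here, compound 2 `O=C1/C(=C/c2ccc(N3CCCC3)cc2)Oc2cc(O)cc(O)c21` gives 391 nM in an assay on isolated protein for inhibition of Amine oxidase [flavin-containing] B (Homo sapiens), read by fluorescence and spectrophotometry, with a stated time of 30 min (on this read-out higher numbers stand for weaker inhibition and lower numbers for stronger inhibition), the lowest number of the two measured so far. The nearest is compound 1 `CN(C)c1ccc(/C=C2\Oc3cc(O)cc(O)c3C2=O)cc1`, which in this assay gives 5940 nM; the step of a 15-fold lower number from compound 1 to compound 2 (1.18 log units; beyond the scatter) shows that the amine group on the aromatic ring moves the number strongly. Compound 3 `CN1CCN(c2ccc(/C=C3\Oc4cc(O)cc(O)c4C3=O)cc2)CC1` carries 4-methylpiperazin-1-yl in place of pyrrolidin-1-yl on an aromatic carbon. Among the compounds with values here, only that one step bears on this change, and it shows the size the group can matter; the direction for a ring with 2 hetero atoms is not fixed by any measured pair. A weaker outcome is expected, with the step of a 3.8-fold higher number from compound 2 to compound 3 (0.58 log units; beyond the scatter). Compound 3 is therefore estimated at 1500 nM, in the range 400 nM to 6000 nM.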

Compound 3, half-maximal inhibitory concentration: 10800 nM
Estimate against measurement, compound 3: 7.2-fold (0.86 log units) below, and the stated range ends below it.
By their numbers in this assay, from the lowest: compound 2; then compounds 1 and 3 (each within the scatter of the next).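

On this aromatic carbon, in this assay, the gain seen with pyrrolidin-1-yl does not extend to 4-methylpiperazin-1-yl: a 28-fold higher number from compound 2 to compound 3 (1.44 log units; beyond the scatter). Set against dimethylamino, the same group gives a 1.8-fold higher number from compound 1 to compound 3 (0.26 log units; within the scatter), so these two groups are not separated here, and of the three groups only pyrrolidin-1-yl stands apart. No measured evidence bears on why these steps occur.

Open, from the compounds shown here alone, is whether the step follows the ring size, the second ring nitrogen or its methyl group. Piperidin-1-yl, morpholin-4-yl and unsubstituted piperazin-1-yl on this carbon would tell these apart.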